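Hydrazide series: pyranone to methylimidazole swap

The source may hold more compounds than are shown below. What is called first, only, known or untested is meant among the compounds shown, and "the series" means these compounds.

Of the compounds shown here, two have been read in a functional assay on HeLa cells (Homo sapiens) for cytotoxicity, read by MTT assay, with a stated time of 48 h; a higher number here means a weaker inhibitor, a lower number a stronger inhibitor. Compound 1 `Cc1ccc(C(=O)c2cc(F)c(OCC(=O)NNC(=O)c3ccc(=O)oc3)c(Cl)c2)cc1` gives 20900 nM and stands at the lower of the two numbers. Compound 2 `O=C(COc1ccc(C(=O)c2ccccc2)cc1)NNC(=O)c1ccc(=O)oc1` gives 99100 nM, a gap beyond the usual scatter. Compound 3 `Cc1ccc(C(=O)c2cc(F)c(OCC(=O)NNC(=O)c3cn(C)cn3)c(Cl)c2)cc1` carries a group of 6 heavy atoms (4 carbon, 2 nitrogen; one five-membered aromatic ring with 2 hetero atoms) in place of a group of 7 heavy atoms (5 carbon, 2 oxygen; one six-membered aromatic ring with 1 hetero atom), on a carbonyl carbon. Among the compounds with values here, no step between measured compounds isolates a change of this kind, so the expectation is anchored on compound 1 alone. For compound 3 a step of a 1.1-fold higher number from compound 1 to compound 3 (0.02 log units; within the scatter) is expected, small and within the scatter in either direction. Compound 3 is therefore estimated at 22000 nM, within 7000 nM to 70000 nM.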

Compound 3, half-maximal inhibitory concentration: 9900 nM
The estimate for compound 3 lay 2.2-fold (0.35 log units) above the measured number; the range from low to high includes it.
By their numbers in this assay, from the lowest: compound 3; then compound 1; then compound 2.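

In this assay the group on the carbonyl carbon whose other neighbours are the amide-type nitrogen proves able to move the read-out: 1-methyl-1H-imidazol-4-yl entering for the six-membered aromatic ring gives a 2.1-fold lower number from compound 1 to compound 3 (0.32 log units; beyond the scatter) as a modest step beyond the scatter. The six-membered ring is thus not needed for this level of cytotoxicity, and a five-membered ring with the same count of hydrogen-bond acceptors serves at least as well. Nothing measured here accounts for the step.

On these data alone, whether the same swap holds on the core of compound 2 remains open. Also open, as far as these compounds go, is how a simple phenyl ring or a carboxylic acid would read at this carbonyl carbon.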